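A few compounds are considered here, and "the series" means these few. Any claim that something is new, unique, unknown or untested is made for them only; others in the source may bear on it.

Measured compounds:
compound 1 `COc1ccc(-c2cc3ccccc3nc2/C=C/C(=O)c2ccccc2)cc1` — 8560 nM
compound 2 `COc1ccc(-c2cc3ccccc3nc2/C=C/C(=O)c2ccc(N)cc2)cc1` — 9290 nM

For the measured compounds named here, in a functional assay on H184B5F5/M10 cells (Homo sapiens) for antiproliferative activity, read by XTT assay, with a stated time of 72 h (on this read-out lower numbers stand for stronger inhibition and higher numbers for weaker inhibition), compound 1 gives 8560 nM, and the only companion is compound 2 at 9290 nM; the step of a 1.1-fold higher number from compound 1 to compound 2 (0.04 log units; within the scatter) is within the scatter, so the two compounds are not distinguished by this read-out, and compound 1 stands alongside compound 2 rather than apart from it.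

Compound 3 `COc1ccc(-c2cc3ccccc3nc2/C=C/C(=O)c2cccs2)cc1` differs from compound 1 in one place: thiophen-2-yl in place of phenyl on a carbonyl carbon. Going by the values given here, no measured step bears directly on this change. Among the compounds with values here, the single step in hand, from compound 1 to compound 2, concerns an amino in place of hydrogen on an aromatic carbon and is in any case within the scatter; it says nothing about exchanging the aryl group attached to the carbonyl carbon. With nothing in the measured pairs pointing either way, the working expectation is that compound 3 stays close to compound 1, with the step of a 1.1-fold lower number from compound 1 to compound 3 (0.03 log units; within the scatter) expected to fall within the scatter. Compound 3 is therefore estimated at 8000 nM, in a range from 3500 nM to 18000 nM.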

Compound 3, half-maximal inhibitory concentration: 7030 nM
Beside the measured number, compound 3's estimate is 1.1-fold (0.06 log units) above it; the range from low to high includes it.
By their numbers in this assay, from the lowest: compounds 3, 1 and 2 (each within the scatter of the next).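

In this assay, the aryl group on the carbonyl carbon is now exchanged as a whole rather than only substituted, giving a 1.2-fold lower number from compound 1 to compound 3 (0.09 log units; within the scatter) for thiophen-2-yl in place of phenyl, and a 1.3-fold lower number from compound 2 to compound 3 (0.12 log units; within the scatter) for thiophen-2-yl in place of 4-aminophenyl. At this position, then, a five-membered aromatic ring with one hetero atom cannot be told apart on this read-out from a six-membered aromatic ring of carbon only, with or without the amino group, and the three compounds form one level with no order among them. No supporting evidence bears on this result.

From the compounds shown here alone, all three compounds keep an aromatic ring on the carbonyl carbon, so it remains open whether the number would hold with a saturated ring such as cyclohexyl, a methyl group, a longer alkyl chain or a carboxylic acid on the phenyl ring. The shared core is also the same throughout, so these compounds do not show whether a change there would move the number beyond the scatter in this assay.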